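Adding an Acetyl Group to the Pendant Phenyl

The source may hold more compounds than are shown below. What is called first, only, known or untested is meant among the compounds shown, and "the series" means these compounds.

Compound 1, `CCOC(=O)c1c(-c2cccc(C(F)(F)F)c2)csc1N`: 9.4 uM
Compound 2, `Nc1scc(-c2cccc(C(F)(F)F)c2)c1C(=O)c1ccccc1`: 15.8 uM
Compound 3, `Nc1sc(-c2ccccc2)c(-c2cccc(C(F)(F)F)c2)c1C(=O)c1ccccc1`: 2.3 uM

These three compounds share one core and were tested in a functional assay on CHO-K1 cells for agonist activity at adenosine receptor A1 (Homo sapiens), read by GTPgammaS binding; on this read-out lower numbers stand for an effect already at smaller amounts and higher numbers for an effect only at larger amounts of compound. Compound 3 gives the lowest number of the three, and its gaps to compound 1 and to compound 2 both lie beyond the scatter. Two single changes connect the measured compounds. Replacing the ethoxy on the carbonyl carbon by phenyl gave a 1.7-fold higher number from compound 1 to compound 2 (0.23 log units; within the scatter). For the measured compounds named here, replacing a hydrogen on an aromatic carbon of the core by phenyl gave a 6.9-fold lower number from compound 2 to compound 3 (0.84 log units; beyond the scatter), the only step that clearly moved the number.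

Compound 4, `CC(=O)c1ccc(-c2sc(N)c(C(=O)c3ccccc3)c2-c2cccc(C(F)(F)F)c2)cc1`, builds on that phenyl: acetyl in place of hydrogen on an aromatic carbon. Going by the values given here, no measured step adds anything to this phenyl, so the data show only that the phenyl itself mattered, and nothing about what a group on it does. The change is therefore expected to give no step beyond the scatter, a 1.2-fold lower number from compound 3 to compound 4 (0.06 log units; within the scatter), with a wide range in either direction. Compound 4 is estimated at 2 uM in this assay, between 0.5 uM and 8 uM.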

Compound 4, concentration for half-maximal effect: > 10 uM
Compound 4 was reported as a limit (the forecaster's own chance of this, stated with the estimate: 5%); middle value at least 5.0-fold (0.69 log units) from the limit.
By their numbers in this assay, from the lowest: compound 3; then compounds 1 and 2 (each within the scatter of the next).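

The earlier compounds shown here showed only that adding the phenyl to the shared core lowered the number; they said nothing about substituents on that ring. Here, in this assay, acetyl in place of hydrogen on the phenyl, para to a large group, gives an at least 4.3-fold higher number from compound 3 to compound 4 (0.63 log units; beyond the scatter), so this ring does not accept every addition without a cost. Compound 4 has no exact value, only a limit: the limit of > 10 uM in this assay, at which 1 of the 4 values shown sits.

As far as these compounds go, that limit leaves the step from compound 2 to compound 4 unreadable, so it stays open whether the 4-acetylphenyl keeps any of the gain seen with the plain phenyl. From the compounds shown here alone, it is also open whether a methyl, a fluorine or an amine at the same place on the ring would move the number the same way as acetyl.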